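Isopropyl for trifluoromethyl on the amide-bearing ring

The compounds below may be only part of what the source reports. "The series", "measured", "known", "first", "only" and "open" are said of these compounds alone.

Compound 1 `Cc1cn(-c2cc(NC(=O)c3ccc(C)c(Nc4nc(-c5cccnc5)cs4)c3)cc(C(F)(F)F)c2)cn1` gives 28 nM in a functional assay on K562 cells (Homo sapiens) for antiproliferative activity; a higher number here means a weaker inhibitor, a lower number a stronger inhibitor. For the measured compounds named here, its only measured neighbour is compound 2 `Cc1ccc(C(=O)Nc2cc(-n3ccnc3)cc(C(F)(F)F)c2)cc1Nc1nc(-c2cccnc2)cs1`, which in this assay gives 28 nM; the step of no change at the digits printed from compound 1 to compound 2 (within the scatter) is hydrogen in place of methyl on an aromatic carbon, and compound 1 stands level with compound 2 on these figures. Compound 3 `Cc1cn(-c2cc(NC(=O)c3ccc(C)c(Nc4nc(-c5cccnc5)cs4)c3)cc(C(C)C)c2)cn1` is unmeasured and differs from compound 1 by isopropyl in place of trifluoromethyl on an aromatic carbon. Going by the values given here, no measured step exchanges trifluoromethyl or touches that carbon, so the single step at hand gives no direction for this change. Compound 3 is expected to give an estimate of 50 nM, with range 15 nM to 200 nM, meaning a step of a 1.8-fold higher number from compound 1 to compound 3 (0.25 log units; within the scatter).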

Compound 3, half-maximal inhibitory concentration: 31 nM
For compound 3 the middle estimate is 1.6-fold (0.21 log units) above the measured one; the range from low to high includes it.
By their numbers in this assay, from the lowest: compounds 1, 2 and 3 (each within the scatter of the next).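

In this assay, for the compounds shown here, the first measured exchange at this carbon, isopropyl in place of trifluoromethyl, gives a 1.1-fold higher number from compound 1 to compound 3 (0.04 log units; within the scatter). Trifluoromethyl is therefore not required at this position for the antiproliferative read-out, as the isopropyl analogue remains within the scatter of the parent. No measured evidence on hand bears on this result.

As far as these compounds go, whether this tolerance extends to an amine, a carboxylic acid or a longer alkyl chain on this carbon remains open. Also open, from the compounds shown here alone, is whether the same exchange on compound 2, which lacks the methyl on its imidazole ring, reads the same way.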